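A few compounds are considered here, and "the series" means these few. Any claim that something is new, unique, unknown or untested is made for them only; others in the source may bear on it.

Measured compounds:
- compound 1, `COc1cc(C(=O)/C=C\Nc2ccc(-c3nc4cc(OC)c(OC)c(OC)c4s3)cc2)c(Br)c(OC)c1OC`, 15600 nM
- compound 2, `COc1cc(C(=O)/C=C\Nc2ccc(-c3nc4cc(OC)c(OC)c(OC)c4s3)cc2C)cc(OC)c1OC`, 12900 nM
- compound 3, `COc1cc(C(=O)/C=C\Nc2ccc(-c3nc4cc(OC)c(OC)c(OC)c4s3)cc2)cc([N+](=O)[O-])c1OC`, 9800 nM

All three were run in a functional assay on MDA-MB-231 cells (Homo sapiens) for antiproliferative activity, read by sulforhodamine B assay, with a stated time of 48 h; a lower number here means a stronger inhibitor, a higher number a weaker inhibitor. Compound 2 gives 12900 nM, the second highest of the three numbers; its nearest neighbour is compound 1 with 15600 nM, a gap that lies within the scatter, and its furthest is compound 3 with 9800 nM, also within the scatter. The three numbers therefore cannot be ordered, and none of the compounds can be called stronger or weaker than another on this evidence.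

The unmeasured compound 4, `COc1ccc(C(=O)/C=C\Nc2ccc(-c3nc4cc(OC)c(OC)c(OC)c4s3)cc2C)cc1F`, differs from compound 2 in one place: 3-fluoro-4-methoxyphenyl in place of 3,4,5-trimethoxyphenyl on a carbonyl carbon. Among the measured compounds shown here, no pair of measured compounds differing in one place is available, so the size of this step has no direct precedent. The three measured values cluster closely whatever their aryl or substituent pattern, which gives no basis for expecting a step beyond the scatter in either direction; the expectation is therefore for little or no change, with the range kept wide to allow for a weakening.

Compound 4 is expected to give 18000 nM in this assay, within 6000 nM to 50000 nM. This estimate implies a step of a 1.4-fold higher number from compound 2 to compound 4 (0.14 log units; within the scatter), expected to fall within the scatter.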

Compound 4, half-maximal inhibitory concentration: 2900 nM
For compound 4 the middle estimate is 6.2-fold (0.79 log units) above the measured one, and the stated range ends above it.
By their numbers in this assay, from the lowest: compound 4; then compounds 3, 2 and 1 (each within the scatter of the next).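

In this assay, among the compounds shown here, the group on the carbonyl carbon is a place where a single change moves the number beyond the scatter: 3-fluoro-4-methoxyphenyl in place of 3,4,5-trimethoxyphenyl gives a 4.4-fold lower number from compound 2 to compound 4 (0.65 log units; beyond the scatter), the first one-place step. The full 3,4,5-trimethoxyphenyl group is therefore not needed for activity in this assay, as the entering group has fewer heavy atoms and fewer hydrogen-bond acceptors and still gives the lower number. No measurement at hand accounts for this step.

Going by these compounds, the change brings in fluorine and removes methoxy groups in one move, so the share of each in the step stays open. Also open, on these data alone, is how the number responds at this place to other groups, such as an unsubstituted phenyl or a pyridyl.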